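This account rests on a few compounds, and the source may have more. Where it says the series, first, only, none or still open, it means among the compounds named here.

In a functional assay on HT-29 cells (Homo sapiens) for antiproliferative activity, read by sulforhodamine B assay, with a stated time of 48 h (a higher number here means a weaker inhibitor, a lower number a stronger inhibitor), three compounds sharing one core differ in a single substituent. Compound 3 `O=C1NCCN1c1ccc(S(=O)(=O)Nc2ccccc2)cc1` gives 280 nM, the lowest number of the three, which makes it the strongest inhibitor so far. Compound 1 `CCCCc1ccc(NS(=O)(=O)c2ccc(N3CCNC3=O)cc2)cc1` gives 610 nM and compound 2 `O=C1NCCN1c1ccc(S(=O)(=O)Nc2ccc(I)cc2)cc1` gives 650 nM. These two cannot be separated, as a 1.1-fold higher number from compound 1 to compound 2 (0.03 log units; within the scatter) shows.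

The next compound is compound 4 `O=C1NCCN1c1ccc(S(=O)(=O)Nc2ccc(OC(F)F)cc2)cc1`, with difluoromethoxy in place of hydrogen on an aromatic carbon, para to a large group: difluoromethoxy in place of hydrogen on an aromatic carbon. Within the data shown here, two measured steps bear on this change: a 2.2-fold lower number from compound 1 to compound 3 (0.34 log units; beyond the scatter) and a 2.3-fold lower number from compound 2 to compound 3 (0.37 log units; beyond the scatter). Both are modest and both lead to hydrogen, so read in reverse, butyl and iodo each sit on the weaker side of hydrogen. Difluoromethoxy itself is untested in this series, but a similarly modest move toward a higher number is expected in this assay. The expected size is a 2.0-fold higher number from compound 3 to compound 4 (0.29 log units; within the scatter). Compound 4 is estimated at 550 nM, with an expected range from 240 nM to 1200 nM.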

Compound 4, half-maximal inhibitory concentration: 650 nM
Compound 4: middle estimate off by 1.2-fold (0.07 log units), on the low side; low and high end bracket the measured number.
By their numbers in this assay, from the lowest: compound 3; then compounds 1, 2 and 4 (each within the scatter of the next).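

In this assay, difluoromethoxy on the aromatic carbon para to a large group also ends on the weaker side of hydrogen, with a 2.3-fold higher number from compound 3 to compound 4 (0.37 log units; beyond the scatter), so compounds 1, 2 and 4 all give higher numbers than compound 3. The three substituents cannot be separated from one another, with no change at the digits printed from compound 2 to compound 4 (within the scatter) and a 1.1-fold higher number from compound 1 to compound 4 (0.03 log units; within the scatter), even though butyl, iodo and difluoromethoxy differ plainly in their atoms. Nothing measured here accounts for the step up from hydrogen or for the shared level of the three substituents.

On these data alone, whether an amine, a hydroxyl or a carboxylic acid at this position would stay near compound 3 at 280 nM or join the other three remains open. As far as these compounds go, how any of these groups would behave elsewhere on the same aromatic ring is also open.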